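The source may report more compounds than this note shows. Statements on the series, on what has been measured and on what is new or still open speak of the compounds shown alone.

Of the compounds shown here, three have so far been measured in a functional assay on HeLa cells (Homo sapiens) for antiproliferative activity; a higher number here means a weaker inhibitor, a lower number a stronger inhibitor. Compound 1, `COCCCO/N=C/c1c(N)ncnc1Oc1ccc2[nH]c(C)cc2c1F`, gives 346 nM, the lowest of the three numbers. Compound 3, `CO/N=C/c1c(N)ncnc1Oc1ccc2[nH]ccc2c1F`, gives 401 nM, a number that lies within the usual scatter of the value for compound 1, so the two cannot be told apart on these data. Compound 2, `CO/N=C/c1c(N)ncnc1Oc1ccc2ncccc2c1`, gives 3430 nM, and its gap to compound 1 is beyond the scatter. Among the compounds with values here, no pair among the three differs in only one place, so no single step between measured compounds can be drawn.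

Compound 4, `Cc1cc2c(F)c(Oc3ncnc(N)c3/C=N/OCCO)ccc2[nH]1`, has not yet been measured. It differs from compound 1 in one place: hydroxy in place of methoxymethyl on a saturated chain carbon, two bonds along the chain from an oxygen on an unsaturated carbon. The chain is cut shorter and ends in a hydroxy group rather than in methoxymethyl.

Because compound 1 with 346 nM and compound 3 with 401 nM sit within the scatter of each other despite carrying different chains, changes of this kind seem to move the number little here. The step of a 1.2-fold higher number from compound 1 to compound 4 (0.06 log units; within the scatter) is therefore expected to be small, most likely within the scatter, in either direction. Compound 4 is estimated at 400 nM, with a range from 150 nM to 1100 nM.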

Compound 4, half-maximal inhibitory concentration: 406 nM
Compound 4: the middle estimate sits 1.0-fold (0.01 log units) below what was measured; the measured number falls inside the stated range.
By their numbers in this assay, from the lowest: compounds 1, 3 and 4 (each within the scatter of the next); then compound 2.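

In this assay, within the data shown here, replacing methoxymethyl with hydroxy on a saturated chain carbon, two bonds along the chain from an oxygen on an unsaturated carbon, gives a 1.2-fold higher number from compound 1 to compound 4 (0.07 log units; within the scatter), the first step in this set that changes only one place. At this place, a group of 3 heavy atoms with 0 hydrogen-bond donors and a group of 1 heavy atom with 1 hydrogen-bond donor therefore cannot be told apart on the shared core of these two compounds, so 3-methoxypropoxy and 2-hydroxyethoxy serve equally well as far as this read-out shows. No measurement in hand explains why the number holds across this change.

This is a single step between two compounds, so it cannot show how far the tolerance extends, and an amine, a carboxylic acid or a much longer chain at the same place could behave differently. It also leaves open whether the same exchange would hold on a core without the methyl group, such as that of compound 3, or on the core of compound 2.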